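From chloro to trifluoromethyl on compound 3

The compounds below may be only part of what the source reports. "The series", "measured", "known", "first", "only" and "open" are said of these compounds alone.

Values measured so far:
Compound 1 `O=C(CCCCC1CCSS1)Nc1cccc(C(F)(F)F)c1` gives 4.39% in the test
Compound 2 `O=C(CCCCC(S)CCS)Nc1ccccc1` gives 4.3% in the test
Compound 3 `O=C(CCCCC(S)CCS)Nc1cccc(Cl)c1` gives 7.2% in the test

In a functional assay on NCI-H460 cells (Homo sapiens) for inhibition, read by MTT assay, with a stated time of 24 h, tested at 1 ug/mL (on this read-out higher numbers stand for more inhibition of growth at the one concentration tested and lower numbers for less inhibition of growth), compound 3 gives 7.2% and stands level with compound 1 and compound 2, with both gaps inside the usual scatter.

Compound 4 `O=C(CCCCC(S)CCS)Nc1cccc(C(F)(F)F)c1` changes one group of compound 3: trifluoromethyl in place of chloro on an aromatic carbon that is, trifluoromethyl in place of chloro on an aromatic carbon.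

Among the compounds with values here, only one measured step concerns this aromatic carbon. It is a number 2.9 percentage points higher from compound 2 to compound 3 (within the scatter) for chloro in place of hydrogen on an aromatic carbon. Compound 1 also carries trifluoromethyl, with the remainder of the molecule different, and gives 4.39% in the same range. Swapping one group for the other is therefore expected to produce no step beyond the scatter in this assay in either direction. The estimated step is a number 1.2 percentage points lower from compound 3 to compound 4 (within the scatter) and stays small. The estimate for compound 4 is 6% with an expected range of 1% to 14% in this measurement.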

Compound 4, percent growth inhibition at one concentration: 8.26%
Estimate against measurement, compound 4: 2.3 percentage points below; the measured number falls inside the stated range.
By their numbers in this assay, from the lowest: compounds 2, 1, 3 and 4 (each within the scatter of the next).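

In this assay this aromatic carbon has now been read with hydrogen, chloro and trifluoromethyl on one shared core, and the third group separates itself from neither of the others: the swap from chloro gives a number 1.1 percentage points higher from compound 3 to compound 4 (within the scatter) and the swap from hydrogen gives a number 4 percentage points higher from compound 2 to compound 4 (within the scatter). Within the data shown here, a second place can also be read for the first time, since replacing the five-membered ring with 2 hetero atoms by the group with no ring, while trifluoromethyl stays in place, gives a number 3.9 percentage points higher from compound 1 to compound 4 (within the scatter) and so also stays inside the scatter. No measurement at hand offers an explanation for these numbers.

Going by these compounds, it remains open whether an amine or a carboxylic acid on this aromatic carbon would give a number beyond the scatter. The same question stands for a longer chain between the carbonyl and the sulfur atoms.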